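A few compounds are considered here, and "the series" means these few. Any claim that something is new, unique, unknown or untested is made for them only; others in the source may bear on it.

Among the compounds with values here, the three compounds measured so far share one core and differ only in the aryl group on a double-bonded chain carbon bound to an aromatic carbon. Compound 1 `C=CCn1c(=O)/c(=C\c2cccc(Cl)c2)[nH]c(=O)/c1=C\c1ccccc1OC` gives 1200 nM in a functional assay on U-937 cells (Homo sapiens) for cytotoxicity, read by CCK-8 assay, with a stated time of 72 h; a lower number here means a stronger inhibitor, a higher number a weaker inhibitor. Compound 2 `C=CCn1c(=O)/c(=C\c2ccccc2Cl)[nH]c(=O)/c1=C\c1ccccc1OC` gives 700 nM in this assay, and compound 3 `C=CCn1c(=O)/c(=C\c2ccccc2C(F)(F)F)[nH]c(=O)/c1=C\c1ccccc1OC` gives 1500 nM. Compound 3 thus carries the highest number of the three, though the gap a 1.3-fold higher number from compound 1 to compound 3 (0.10 log units; within the scatter) lies within the scatter, while the gap a 2.1-fold higher number from compound 2 to compound 3 (0.33 log units; beyond the scatter) is modest and beyond it.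

Compound 4 `C=CCn1c(=O)/c(=C\c2ccc(F)c(Br)c2)[nH]c(=O)/c1=C\c1ccccc1OC` is not yet measured. Relative to compound 3 the change is 3-bromo-4-fluorophenyl in place of 2-(trifluoromethyl)phenyl on a double-bonded chain carbon bound to an aromatic carbon. Within the data shown here, no measured step swaps the trifluoromethylphenyl for a dihalogenated phenyl, so the nearest guides are the halogen-bearing compounds: the step of a 1.7-fold lower number from compound 1 to compound 2 (0.23 log units; within the scatter) stays within the scatter, and the step of a 2.1-fold higher number from compound 2 to compound 3 (0.33 log units; beyond the scatter) is the only one beyond it. Since compound 4 returns to a halogenated aryl, a number near those of compounds 1 and 2 is expected, which would mean a step of a 1.5-fold lower number from compound 3 to compound 4 (0.18 log units; within the scatter), expected to be small and toward a lower number. Compound 4 is therefore estimated at 1000 nM in this assay, with a range from 400 nM to 2500 nM.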

Compound 4, half-maximal inhibitory concentration: "not active" (no number reported)
Compound 4: no number reported; no gap can be computed for the estimate.
By their numbers in this assay, from the lowest: compounds 2, 1 and 3 (each within the scatter of the next, the first and the last beyond it).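

In this assay, within the data shown here, compound 4 is reported as "not active" without a number, so no step linking it to compound 3 or any other compound can be read. The compounds shown leave open where compound 4 stands numerically and what the bromine and the fluorine of its 3-bromo-4-fluorophenyl each contribute. Nothing available explains this result.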